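Fluoro on the benzyl ring of a pyrazolone amide

The compounds below may be only part of what the source reports. "The series", "measured", "known", "first", "only" and "open" are said of these compounds alone.

Three measured compounds share the same kind of pyrazolone amide arrangement. Compound 1 `COc1cccc(Cc2cc(-c3ccccc3)nn(CC(=O)Nc3ccc(F)cc3)c2=O)c1` was tested in an assay on HL-60 cells for agonist activity at N-formyl peptide receptor 3 (Homo sapiens), read by calcium flux; on this read-out lower numbers stand for an effect already at smaller amounts and higher numbers for an effect only at larger amounts of compound. In this assay compound 1 gives only a limit of the assay, > 50000 nM. Compound 2 `COc1cccc(Cc2cc(-c3ccc(F)cc3)nn(CC(=O)Nc3ccc(F)cc3)c2=O)c1` differs from it by the change (fluoro in place of hydrogen on an aromatic carbon). In this assay compound 2 likewise gives only a limit, > 50000 nM. The step that the two limits leave unreadable from compound 1 to compound 2 therefore cannot be sized, because the limit of > 50000 nM in this assay, at which 3 of the 3 values shown sit, holds both ends of it. Compound 3 `Cc1cc(Cc2ccccc2)c(=O)n(CC(=O)Nc2ccc(Br)cc2)n1` carries a different core; how its core differs from that of compound 1 is not broken down here. In this assay compound 3 also gives only a limit, > 50000 nM.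

Compound 4 `Cc1cc(Cc2cccc(F)c2)c(=O)n(CC(=O)Nc2ccc(Br)cc2)n1` is not yet measured. It differs from compound 3 by fluoro in place of hydrogen on an aromatic carbon. Within the data shown here, this is the same kind of change as the one from compound 1 to compound 2, but there the fluoro sat para to a large group, whereas here it sits meta to a large group. Since all three measured values sit at the limit described in the limit of > 50000 nM in this assay, at which 3 of the 3 values shown sit, compound 4 is expected to remain there, with an estimated step that the limit leaves unreadable from compound 3 to compound 4 and an estimated value of 60000 nM.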

Compound 4, half-maximal effective concentration: > 50000 nM
Compound 4: no number, only a limit (the forecaster's own chance of this, stated with the estimate: 85%); the middle value is on the limit's open side.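

The step from compound 3 to compound 4 cannot be read in this assay, since both compounds stand only at a limit of the assay, as do compound 1 and compound 2: the limit of > 50000 nM in this assay, at which 4 of the 4 values shown sit. The compounds shown leave open whether fluoro in place of hydrogen changes anything in this assay and what kind of compound would give a number there.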